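The compounds below may be only part of what the source reports. "The series", "measured", "known", "first", "only" and "open" are said of these compounds alone.

Compound 1 `CN(c1cccc2c1CCCC2c1c[nH]cn1)S(C)(=O)=O`: 912 nM
Compound 2 `CC(=O)Nc1cccc2c1CCCC2c1c[nH]cn1`: 3020 nM

Among the measured compounds shown here, of these two measured compounds, compound 2 gives the higher number in an assay on isolated protein for binding affinity to Alpha-2B adrenergic receptor (Rattus norvegicus), read by radioligand binding (on this read-out lower numbers stand for stronger inhibition and higher numbers for weaker inhibition), and the only step that has been measured is a 3.3-fold higher number from compound 1 to compound 2 (0.52 log units; beyond the scatter). Compound 3 `O=C(Nc1cccc2c1CCCC2c1c[nH]cn1)C(F)(F)F` differs from compound 2 by trifluoromethyl in place of methyl on a carbonyl carbon. For the measured compounds named here, no measured step bears directly on this change: the one known step exchanges the whole group on the aromatic carbon, whereas here the amide is kept and only the group on its carbonyl carbon is exchanged. With nothing to point to a direction, the expectation for compound 3 is a number close to that of compound 2, not beyond the usual scatter, which amounts to a 1.2-fold lower number from compound 2 to compound 3 (0.08 log units; within the scatter). Compound 3 is therefore estimated at 2500 nM, with a range from 800 nM to 8000 nM.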

Compound 3, inhibition constant: 661 nM
Compound 3: the middle estimate sits 3.8-fold (0.58 log units) above what was measured, and the stated range ends above it.
By their numbers in this assay, from the lowest: compounds 3 and 1 (each within the scatter of the next); then compound 2.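

In this assay, keeping the amide and exchanging only the group on its carbonyl carbon gives a 4.6-fold lower number from compound 2 to compound 3 (0.66 log units; beyond the scatter) and so shows that the number depends on this small part of the group, not only on the type of group attached to the aromatic carbon. Exchanging the whole group, ((trifluoromethyl)carbonyl)amino in place of methyl(methylsulfonyl)amino, gives a 1.4-fold lower number from compound 1 to compound 3 (0.14 log units; within the scatter) and leaves these two compounds indistinguishable here, although acetamido stood apart from methyl(methylsulfonyl)amino. The available data offer no measurement that explains the effect of trifluoromethyl.

The compounds shown leave open whether a longer chain such as ethyl, or a fluoromethyl group, on the same carbonyl carbon would shift the number in the same way. They also leave open how a plain amine on the aromatic carbon would compare with these amides.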